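A few compounds are considered here, and "the series" means these few. Any claim that something is new, unique, unknown or untested is made for them only; others in the source may bear on it.

For the measured compounds named here, compound 2 `N=C(N)c1ccc2oc(-c3cccc(OCCCCOc4ccccc4)c3)cc2c1` gives the lowest of the two numbers measured so far: in an ADME assay on L6 cells (Rattus norvegicus) for cytotoxicity, read by resazurin assay, with a stated time of 70 h (a higher number here means a weaker inhibitor, a lower number a stronger inhibitor), compound 2 gives 8100 nM, while compound 1 `CC(C)NC(=N)c1ccc2oc(-c3cccc(OCCCOc4ccccc4)c3)cc2c1`, which differs from it in several places, gives 26500 nM in this assay. Compound 3 `CC(C)NC(=N)c1ccc2oc(-c3cccc(OCCCCOc4ccccc4)c3)cc2c1` differs from compound 2 by one change, (isopropyl in place of hydrogen on an amine nitrogen), isopropyl in place of hydrogen on an amine nitrogen. Compound 1 carries the same isopropylamino group and sits higher, but it differs elsewhere as well, so no single step can be read from those two numbers. Compound 3 is nonetheless expected to move toward the higher number, by a step of a 2.5-fold higher number from compound 2 to compound 3 (0.39 log units; beyond the scatter) beyond the scatter. The estimate for compound 3 in this assay is 20000 nM, within 8000 nM to 50000 nM.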

Compound 3, half-maximal inhibitory concentration: 36500 nM
Estimate against measurement, compound 3: 1.8-fold (0.26 log units) below; the measured number falls inside the stated range.
By their numbers in this assay, from the lowest: compound 2; then compounds 1 and 3 (each within the scatter of the next).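

In this assay the change from amino to isopropylamino on the amine nitrogen now stands as a single step: a 4.5-fold higher number from compound 2 to compound 3 (0.65 log units; beyond the scatter) and so beyond the scatter. Phenoxymethyl in place of phenoxy on a saturated chain carbon gives a 1.4-fold higher number from compound 1 to compound 3 (0.14 log units; within the scatter) and leaves the two isopropylamino compounds within the scatter of each other. No measurement at hand gives a reason for either step.

Going by these compounds, whether cyclopropyl or tert-butyl on that amine nitrogen gives a step of like size stays open. So does whether a longer chain than that of compound 3 stays within the scatter.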